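A few compounds are considered here, and "the series" means these few. Any claim that something is new, unique, unknown or untested is made for them only; others in the source may bear on it.

Measured so far:
compound 1 `N#Cc1ccc(-c2nc(N)c3cc(Cc4ccccc4)sc3n2)o1` — 3160 nM
compound 2 `N#Cc1cccc(-c2nc(N)c3cc(Cc4ccccc4)sc3n2)c1` — 222 nM

Among the compounds with values here, in a functional assay on CHO-K1 cells for antagonist activity at adenosine receptor A1 (Homo sapiens), read by a beta-galactosidase reporter and cAMP accumulation, with stated times of 15 min and 6 h (on this read-out lower numbers stand for stronger inhibition and higher numbers for weaker inhibition), compound 2 gives the lowest of the two numbers; the only other measured compound, compound 1, sits well apart, as the step of a 14-fold lower number from compound 1 to compound 2 (1.15 log units; beyond the scatter) shows. Compound 3 `COc1cccc(-c2nc(N)c3cc(Cc4ccccc4)sc3n2)c1` keeps the shared core and the six-membered carbon ring of compound 2 and alters only the substituent on that ring: methoxy in place of cyano on an aromatic carbon, placed meta to a large group. Within the data shown here, no measured step touches this substituent; the one step recorded, a 14-fold lower number from compound 1 to compound 2 (1.15 log units; beyond the scatter), exchanges the whole aromatic ring rather than a group on it, so it gives the scale of what a change at this part of the molecule can do without telling the direction for methoxy against cyano. With a single large step that does not bear directly on the change, the expectation is cautious: compound 3 is estimated to lie near compound 2, with a slight drift toward weaker inhibition allowed for, as the expected step of a 2.0-fold higher number from compound 2 to compound 3 (0.31 log units; beyond the scatter) expresses. The estimate for compound 3 in this assay is 450 nM, within 150 nM to 1500 nM.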

Compound 3, inhibition constant: 266 nM
Compound 3: middle estimate off by 1.7-fold (0.23 log units), on the high side; the range from low to high includes it.
By their numbers in this assay, from the lowest: compounds 2 and 3 (each within the scatter of the next); then compound 1.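

In this assay, within the data shown here, cyano and methoxy on an aromatic carbon, meta to a large group, are not told apart on the six-membered carbon ring (a 1.2-fold higher number from compound 2 to compound 3 (0.08 log units; within the scatter)), so this position so far accepts either group with no reading beyond the scatter. The 5-cyanofuran-2-yl compound now stands well apart from both of the phenyl compounds (a 12-fold lower number from compound 1 to compound 3 (1.07 log units; beyond the scatter)), and since compound 1 shares its cyano group with compound 2 but not with compound 3, the large gap among these three goes with the exchange of the aromatic ring and not with the cyano group itself. Nothing available on these compounds gives a measured reason for either reading.

What remains open is how far this tolerance extends, since only two substituents at this one place are shown, and an amine, a carboxylic acid or a longer alkoxy chain there might or might not read like cyano and methoxy. Also open, on these data alone, is whether the phenyl ring needs any substituent at all, and whether a methoxy group on the furan ring would read like the cyano group of compound 1.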